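A few compounds are considered here, and "the series" means these few. Any claim that something is new, unique, unknown or untested is made for them only; others in the source may bear on it.

Measured compounds:
compound 1 `CC1(OC(=O)N2C[C@H]3COC[C@@H](C2)[C@@H]3Oc2ncnc(Nc3ccccc3F)c2F)CC1`: 25 nM
compound 2 `N#Cc1ccc(Nc2ncnc(OC3C4COCC3CN(C(=O)OC3CCC3)C4)c2F)c(Cl)c1`: 60 nM

In a functional assay for agonist activity at Glucose-dependent insulinotropic receptor (Mus musculus), read by cAMP accumulation (on this read-out lower numbers stand for an effect already at smaller amounts and higher numbers for an effect only at larger amounts of compound), compound 1 stands lowest of the two numbers; compound 2 gives 60 nM and sits beyond the scatter from it. Compound 3 `CC1(OC(=O)N2C[C@H]3COC[C@@H](C2)[C@@H]3Oc2ncnc(Nc3c(F)cccc3F)c2F)CC1` is not yet measured and differs from compound 1 by fluoro in place of hydrogen on an aromatic carbon. Going by the values given here, no measured pair shows this change, so the direction is open; a step no larger than the scatter is expected, with a slight lean toward a higher number. Compound 3 is therefore estimated at 32 nM in this assay, within 12 nM to 80 nM, which means an expected step of a 1.3-fold higher number from compound 1 to compound 3 (0.11 log units; within the scatter).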

Compound 3, half-maximal effective concentration: 113 nM
Compound 3: the middle estimate sits 3.5-fold (0.55 log units) below what was measured; the measured number lies above the stated range.
By their numbers in this assay, from the lowest: compound 1; then compounds 2 and 3 (each within the scatter of the next).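

In this assay, going by these compounds alone, going from (2-fluorophenyl)amino to (2,6-difluorophenyl)amino gives a 4.5-fold higher number from compound 1 to compound 3 (0.66 log units; beyond the scatter), the first single-place step. This aromatic carbon is therefore not indifferent to substitution: one added fluoro, ortho to a large group, moves the number beyond the scatter and in the unfavourable direction. Nothing available accounts for this step. On these data alone, whether chloro, methyl or methoxy on this carbon would give a similar step remains open. So does whether the fluoro step carries over to the differently substituted phenyl ring of compound 2.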